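Naphthyl for Phenyl on the Sulfonamide-Diamine Scaffold

This account rests on a few compounds, and the source may have more. Where it says the series, first, only, none or still open, it means among the compounds named here.

Of the compounds shown here, three sharing one core have been tested in a functional assay on A2780 cells (Homo sapiens) for inhibition, read by MTT assay, with a stated time of 72 h; a higher number here means a weaker inhibitor of growth, a lower number a stronger inhibitor of growth. Compound 1 `O=S(=O)(NCCCNCc1ccc(Cl)c(Cl)c1)c1cc(C(F)(F)F)cc(C(F)(F)F)c1` gives 1500 nM, compound 2 `O=S(=O)(NCCCNCC1COc2ccccc2O1)c1cc(C(F)(F)F)cc(C(F)(F)F)c1` gives 1500 nM, and compound 3 `O=S(=O)(NCCCNCc1ccccc1)c1cc(C(F)(F)F)cc(C(F)(F)F)c1` gives 4900 nM. Compound 3 therefore stands with the highest number of the three, and its distance from each neighbour is beyond the scatter: a 3.3-fold higher number from compound 1 to compound 3 (0.51 log units; beyond the scatter) and a 3.3-fold higher number from compound 2 to compound 3 (0.51 log units; beyond the scatter). The step of no change at the digits printed from compound 1 to compound 2 (within the scatter) shows that compounds 1 and 2 cannot be told apart in this assay.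

Compound 4 `O=S(=O)(NCCCNCc1cccc2ccccc12)c1cc(C(F)(F)F)cc(C(F)(F)F)c1` differs from compound 3 by one change: naphthalen-1-yl in place of phenyl on a saturated chain carbon bound to an amine nitrogen. The two measured steps that bear on this are the ones in which the ring on that chain carbon was changed, and both ran the same way: replacing a larger ring by plain phenyl raised the number, each time by a modest amount. Going from phenyl to the larger naphthalen-1-yl is the reverse direction of that kind of change, so a modest fall in the number is expected, of about the size seen in those two steps, with the change printed as a 3.1-fold lower number from compound 3 to compound 4 (0.49 log units; beyond the scatter). On that basis compound 4 is estimated at 1600 nM, with a range from 600 nM to 4500 nM.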

Compound 4, concentration for 50% growth inhibition: 3100 nM
Beside the measured number, compound 4's estimate is 1.9-fold (0.29 log units) below it; the measured number falls inside the stated range.
By their numbers in this assay, from the lowest: compounds 1 and 2 (each within the scatter of the next); then compounds 4 and 3 (each within the scatter of the next).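

In this assay, enlarging phenyl to naphthalen-1-yl, with 2 six-membered aromatic rings of carbon only in place of one, gives a step that cannot be told from noise (a 1.6-fold lower number from compound 3 to compound 4 (0.20 log units; within the scatter)). The comparisons with the other two compounds separate compound 4 from both (a 2.1-fold higher number from compound 1 to compound 4 (0.32 log units; beyond the scatter); a 2.1-fold higher number from compound 2 to compound 4 (0.32 log units; beyond the scatter)), so among these four compounds, the larger size of the carbon ring system does not by itself match the lower numbers seen with 3,4-dichlorophenyl and 2,3-dihydro-1,4-benzodioxin-2-yl. Nothing available here accounts for this difference between the ring groups.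

The compounds shown leave open which feature of the 3,4-dichlorophenyl group matters, and a phenyl ring bearing a single chlorine, or a pyridine ring in the same place, would help to narrow that down. They also leave open whether the small gaps at this position would persist with a longer chain linking the two nitrogens of the shared core.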